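The source may hold more compounds than are shown below. What is called first, only, known or untested is meant among the compounds shown, and "the series" means these compounds.

Compound 1 `CC(=O)NC(CCC(=O)NC(CSCc1ccc(Br)cc1)C(=O)NCC(=O)O)C(=O)O`: in a functional assay on K562 cells (Homo sapiens) for cytotoxicity (a higher number here means a weaker inhibitor, a lower number a stronger inhibitor), compound 1 gives > 50 uM, a limit of the assay.
Compound 2 `O=C(O)CNC(=O)C(CSCc1ccc(Br)cc1)NC(=O)CCC(NC(=O)OCc1ccccc1)C(=O)O`: in this assay compound 2 gives > 50 uM, also a limit.

Neither compound has a measured number, only a limit. For the measured compounds named here, the one measured step, a step that the two limits leave unreadable from compound 1 to compound 2, cannot be sized because of the limit of > 50 uM in this assay, at which 2 of the 2 values shown sit. Compound 2 therefore stands at that limit and nowhere more precise. Compound 3 `NC(=O)CNC(=O)C(CSCc1ccc(Br)cc1)NC(=O)CCC(NC(=O)OCc1ccccc1)C(=O)O` differs from compound 2 by amino in place of hydroxy on a carbonyl carbon. No measured step covers this change, so nothing shown points to a gain or a loss beyond the usual scatter. Compound 3 is expected to stay near the limit, with an estimated step that the limit leaves unreadable from compound 2 to compound 3 giving 80 uM, range 30 uM to 250 uM.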

Compound 3, concentration for 50% inhibition: > 50 uM
Compound 3: no number, only a limit; the forecaster's own chance of this, stated with the estimate: 80%; the middle value does not contradict the limit.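

No step can be read from compound 2 to compound 3, because both give only a limit, not a number: the limit of > 50 uM in this assay, at which 3 of the 3 values shown sit.

The compounds shown leave open how strong any of the three is in this assay, and whether amino in place of hydroxy on a carbonyl carbon changes anything.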